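Adding chloro to compound 2

A few compounds are considered here, and "the series" means these few. Any claim that something is new, unique, unknown or untested is made for them only; others in the source may bear on it.

Compound 1 `Cc1c(S(=O)(=O)N/C(=N\O)Nc2ccc(Cl)c(Cl)c2)sc2ccc(Cl)cc12` reads > 300 ug/mL in a functional assay on HepG2 cells (Homo sapiens) for cytotoxicity (a lower number here means a stronger inhibitor, a higher number a weaker inhibitor), which is a limit of the assay and not a number. Of the two actual numbers, compound 2 `Cc1ccc(S(=O)(=O)/N=C(\S)Nc2ccc(Cl)cc2)cc1` stands highest at 232 ug/mL in this series. Compound 3 `Cc1c(S(=O)(=O)/N=C(\S)Nc2ccc(Cl)cc2)sc2ccc(Cl)cc12` lies lower at 57 ug/mL, a gap beyond the usual scatter.

Compound 4 `Cc1ccc(S(=O)(=O)/N=C(\S)Nc2ccc(Cl)c(Cl)c2)cc1` differs from compound 2 by a single change, (chloro in place of hydrogen on an aromatic carbon), which is chloro in place of hydrogen on an aromatic carbon, ortho to a chloro group and meta to a large group. Going by the values given here, no measured pair isolates this change, so the expectation rests on little. Among the compounds with values here, the lower number of compound 3 at 57 ug/mL shows only that values well under that of compound 2 occur.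

Expected in this assay is a modest fall in the number, a 1.5-fold lower number from compound 2 to compound 4 (0.16 log units; within the scatter), which may not clear the scatter. Compound 4 is estimated at 160 ug/mL, with an expected range of 70 ug/mL to 300 ug/mL for four of five measurements.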

Compound 4, half-maximal inhibitory concentration: 120 ug/mL
Compound 4: middle estimate off by 1.3-fold (0.12 log units), on the high side; measured number inside the range.
By their numbers in this assay, from the lowest: compound 3; then compounds 4 and 2 (each within the scatter of the next). At a limit, above all of these: compound 1.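

In this assay, chloro in place of hydrogen on an aromatic carbon, ortho to a chloro group and meta to a large group, gives a 1.9-fold lower number from compound 2 to compound 4 (0.29 log units; within the scatter), so this position accepts the added chloro without a change that can be told from the scatter. Going by these compounds alone, this is the first pair to isolate the change, and it reads the change on the core of compound 2 alone. No measurement shown gives a cause for this step.

Open, from the compounds shown here alone, is whether the same chloro gives a similar step on the core of compound 3, which differs from compound 4 in more than one place. Also open, going by these compounds, is whether a different group at this position, such as an amine, a carboxylic acid or a methoxy group, would give a step beyond the scatter.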